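Benzylsulfanyl oxadiazole coumarins: halogen pattern swap

This account rests on a few compounds, and the source may have more. Where it says the series, first, only, none or still open, it means among the compounds named here.

Measured compounds in a functional assay on MCF7 cells (Homo sapiens) for antiproliferative activity, read by MTT assay, with a stated time of 24 h; on this read-out lower numbers stand for stronger inhibition and higher numbers for weaker inhibition:
- compound 1, `CCSc1nnc(COc2cc(C)c3c(C)cc(=O)oc3c2)o1`: > 100000 nM
- compound 2, `CCCCCSc1nnc(COc2cc(C)c3c(C)cc(=O)oc3c2)o1`: > 100000 nM
- compound 3, `Cc1cc(OCc2nnc(SCc3ccc(F)c(F)c3)o2)cc2oc(=O)cc(C)c12`: 33300 nM

Compound 1 reports only a limit, (the limit of > 100000 nM in this assay, at which 2 of the 3 values shown sit). Compound 2 likewise sits at that limit. Compound 3 gives the only number shown in this assay; the step of an at least 3.0-fold lower number from compound 1 to compound 3 (0.47 log units; beyond the scatter) and the step of an at least 3.0-fold lower number from compound 2 to compound 3 (0.47 log units; beyond the scatter) are both read against limits, so their true size is not known beyond being at least modest. The step that the two limits leave unreadable from compound 1 to compound 2 cannot be read at all.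

Compound 4, `Cc1cc(OCc2nnc(SCc3ccc(Cl)cc3Cl)o2)cc2oc(=O)cc(C)c12`, differs from compound 3 only at the sulfur-bound chain carbon: 2,4-dichlorophenyl in place of 3,4-difluorophenyl on a saturated chain carbon bound to a sulfur. Both measured steps that touch this position replace an alkyl group with an aryl group; none compares one halogenated phenyl with another. Among the compounds with values here, the present change keeps the aryl group and changes only the halogens and their pattern, so no measured step bears directly on it. Compound 4 is expected to remain in the range of compound 3, with the step of a 1.1-fold lower number from compound 3 to compound 4 (0.05 log units; within the scatter) estimated to lie within the usual scatter. For compound 4 the expected value in this assay is 30000 nM, between 10000 nM and 100000 nM.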

Compound 4, half-maximal inhibitory concentration: < 5000 nM
Compound 4 gave a limit, no number; the forecaster's own chance of this, stated with the estimate: 25%; at least 6.0-fold (0.77 log units) between middle value and limit.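

In this assay compound 4 reports only a limit, not a number: the limit of < 5000 nM in this assay, at which 1 of the 4 values shown sits.

The aryl group at the sulfur-bound chain carbon is therefore not a fixed unit: with the ring kept, the swap of 3,4-difluorophenyl for 2,4-dichlorophenyl gives an at least 6.6-fold lower number from compound 3 to compound 4 (0.82 log units; beyond the scatter), so the halogens and their pattern matter at this position, which the earlier alkyl-to-aryl steps could not show. Set against the alkyl compounds, the same group gives an at least 20-fold lower number from compound 2 to compound 4 (1.30 log units; beyond the scatter) and an at least 20-fold lower number from compound 1 to compound 4 (1.30 log units; beyond the scatter), and since both of these steps rest on limits at each end, their true size stays unknown beyond the bound printed with them.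

Going by these compounds, what remains open is whether the gain follows the change of halogen or the change of pattern, since the two moved together; 2,4-difluorophenyl or 3,4-dichlorophenyl at this position would separate them. Also open, on these data alone, are how far the true value of compound 4 lies past its limit and whether an unsubstituted phenyl, or a ring carrying a methoxy group or an amine in place of the halogens, would hold the effect.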